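Shifting the Chlorine on the Aromatic Ring: Compound 4

The source may report more compounds than this note shows. Statements on the series, on what has been measured and on what is new or still open speak of the compounds shown alone.

Compound 1 `CCC(C(=O)N1CCN(c2ccccc2Cl)CC1)N1C(=O)CCC1=O` was tested in a functional assay on the whole organism (strain Swiss) with Mus musculus as the target, in the maximal electroshock model, with a stated time of 2 h, at a dose of 300 mg/kg by the intraperitoneal route (on this read-out higher numbers stand for a stronger effect at the one dose given and lower numbers for a weaker effect), where compound 1 gives 0%. Two close relatives were measured alongside it. Compound 2 `CCC(C(=O)N1CCN(c2ccccc2C(F)(F)F)CC1)N1C(=O)CCC1=O` carries trifluoromethyl in place of chloro on an aromatic carbon, and in this assay compound 2 gives 0%; the step is no change at the digits printed from compound 1 to compound 2 (within the scatter). Compound 3 `CC(C(=O)N1CCN(c2ccccc2Cl)CC1)N1C(=O)CCC1=O` has hydrogen in place of methyl on a saturated chain carbon, and in this assay compound 3 gives 0%; here no change at the digits printed from compound 1 to compound 3 (within the scatter). Compound 1 thus stands level with compounds 2 and 3 on this read-out, with no activity recorded for any of the three.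

Compound 4 `CCC(C(=O)N1CCN(c2cccc(Cl)c2)CC1)N1C(=O)CCC1=O` has not yet been measured. It differs from compound 1 only in the group attached on an amine nitrogen in a ring: 3-chlorophenyl in place of 2-chlorophenyl on an amine nitrogen in a ring. Neither measured step bears directly on this change, since one swaps the group itself and the other alters the chain, and both were within the scatter. Nothing in these data points to a gain, so the expected step of no change at the digits printed from compound 1 to compound 4 (within the scatter) is none beyond the scatter. Compound 4 is therefore estimated at 0%, with a range from 0% to 25%.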

Compound 4, a percentage reported as activity, at one dose (the size of the read-out at that dose, not a potency): 25%
Compound 4: the middle estimate sits 25 percentage points below what was measured; low and high end bracket the measured number.
By their numbers in this assay, from the lowest: compounds 1, 2 and 3 (each within the scatter of the next); then compound 4.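

In this assay, 3-chlorophenyl in place of 2-chlorophenyl on the amine nitrogen in a ring gives a number 25 percentage points higher from compound 1 to compound 4 (beyond the scatter), the only step shown that lies beyond the scatter. The two groups have the same heavy atoms, so compound 1 and compound 4 differ only in how those atoms are joined, and this shows that the read-out can respond to the chlorine's place on the aromatic ring, even though swapping chloro for trifluoromethyl gave no change at the digits printed from compound 1 to compound 2 (within the scatter) with the chlorine's place unchanged from compound 1. The data shown offer no measurement that explains this difference.

Going by these compounds, whether the gain is tied to chlorine itself remains open, and a plain phenyl group, or a methoxy or trifluoromethyl group in the place the chlorine holds in 3-chlorophenyl, would help to separate the effect of the atom from that of its place. Also open, on these data alone, is whether the shorter chain of compound 3 would make any difference when combined with 3-chlorophenyl, and, with a single dose, how potent compound 4 is.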